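The source may hold more compounds than are shown below. What is called first, only, known or untested is meant among the compounds shown, and "the series" means these compounds.

In a functional assay on P388 cells (Mus musculus) for cytotoxicity (on this read-out higher numbers stand for weaker inhibition and lower numbers for stronger inhibition), three compounds built on a shared core have been measured so far. Compound 1 `COc1ccc(C[C@H]2C(=O)N[C@@H](C)C(=O)N(C)[C@H]3Cc4ccc(cc4)Oc4cc(ccc4OC)C[C@@H](C(=O)N[C@H](C)C(=O)N[C@@H](CCCN=[N+]=[N-])C(=O)N2C)N(C)C3=O)cc1` gives 35.5 nM and compound 3 `C=CCN1C(=O)[C@@H](C)NC(=O)[C@@H]2Cc3ccc(OC)c(c3)Oc3ccc(cc3)C[C@@H](C(=O)N2C)N(C)C(=O)[C@H](C)NC(=O)[C@H](Cc2ccc(OC)cc2)N(C)C(=O)[C@@H]1C` gives 18.6 nM, so these two sit within the scatter of each other and form the upper pair of the three numbers. Compound 2 `CCCN1C(=O)[C@@H](C)NC(=O)[C@@H]2Cc3ccc(OC)c(c3)Oc3ccc(cc3)C[C@@H](C(=O)N2C)N(C)C(=O)[C@H](C)NC(=O)[C@H](Cc2ccc(OC)cc2)N(C)C(=O)[C@@H]1C` lies clearly lower at 3.98 nM.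

Compound 4 `COc1ccc(C[C@H]2C(=O)N[C@@H](C)C(=O)N(C)[C@H]3Cc4ccc(cc4)Oc4cc(ccc4OC)C[C@@H](C(=O)N[C@H](C)C(=O)N(CC=C(C)C)[C@@H](C)C(=O)N2C)N(C)C3=O)cc1` has not yet been measured. It differs from compound 3 as follows: 2-methylprop-1-en-1-yl in place of vinyl on a saturated chain carbon bound to an amide-type nitrogen in a ring. Put simply, it has 2-methylprop-1-en-1-yl in place of vinyl on a saturated chain carbon bound to an amide-type nitrogen in a ring.

Within the data shown here, the one measured step at this place is a 4.7-fold higher number from compound 2 to compound 3 (0.67 log units; beyond the scatter), a modest rise that came with vinyl replacing ethyl. Among the measured compounds shown here, a single step cannot establish a trend, and no measured compound carries the incoming group, so the direction is uncertain. Even so, another modest rise in the number is expected, and the estimated step is a 2.4-fold higher number from compound 3 to compound 4 (0.38 log units; beyond the scatter). For compound 4 the estimated value is 45 nM, with an expected range from 12 nM to 160 nM.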

Compound 4, half-maximal inhibitory concentration: 6.92 nM
Compound 4: middle estimate off by 6.5-fold (0.81 log units), on the high side; measured number below the stated range.
By their numbers in this assay, from the lowest: compounds 2 and 4 (each within the scatter of the next); then compounds 3 and 1 (each within the scatter of the next).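

In this assay, replacing the allyl group of compound 3 with 3-methylbut-2-en-1-yl gives a 2.7-fold lower number from compound 3 to compound 4 (0.43 log units; beyond the scatter), so the rise seen on going from ethyl to vinyl does not continue as this group grows. Against the ethyl group, the same change gives a 1.7-fold higher number from compound 2 to compound 4 (0.24 log units; within the scatter), which leaves the larger group and the ethyl group indistinguishable here and shows that the number does not move steadily in one direction with group size, with compound 3 going against any such trend. Nothing shown bears on why the numbers fall this way.

Still open, as far as these compounds go, is how this place responds to a group that is not a plain hydrocarbon, such as an amine or a carboxylic acid at the end of the chain. A longer saturated chain, such as hexyl, would show whether the ethyl-like number holds without a double bond.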